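Swapping 2-cyanoethyl for 2-cyanoethenyl on a shared core

The compounds below may be only part of what the source reports. "The series", "measured", "known", "first", "only" and "open" are said of these compounds alone.

Measured so far in a physicochemical assay for lipophilicity, at pH 7.4; on this read-out lower numbers stand for lower lipophilicity and higher numbers for higher lipophilicity:

- compound 1 (`Cc1cc(/C=C/C#N)cc(C)c1Oc1cc(Nc2ccc(C#N)cc2)c(N)cc1C(N)=O`) gives 3.53
- compound 2 (`Cc1cc(CCC#N)cc(C)c1Oc1cc(Nc2ccc(C#N)cc2)c(N)cc1CO`) gives 3.68

Compound 2 stands within the usual scatter of compound 1, so these two values cannot be told apart. Compound 3 (`Cc1cc(/C=C/C#N)cc(C)c1Oc1cc(Nc2ccc(C#N)cc2)c(N)cc1CO`) is still unmeasured. It differs from compound 2 in one place: 2-cyanoethenyl in place of 2-cyanoethyl on an aromatic carbon. Going by the values given here, no measured pair shows this change alone. Compound 1, which carries 2-cyanoethenyl, gives 3.53 and compound 2 gives 3.68 in this assay so no shift beyond the scatter is expected. The expected step is a number 0.02 log units higher from compound 2 to compound 3 (within the scatter) and no larger. Compound 3 is estimated at 3.7 with an expected range of 3.4 to 4 in this assay when measured.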

Compound 3, partition coefficient: 4.14
Compound 3: the middle estimate sits 0.44 log units below what was measured, and the stated range ends below it.
By their numbers in this assay, from the lowest: compounds 1 and 2 (each within the scatter of the next); then compound 3.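

In this assay, this position proves sensitive to a small change: 2-cyanoethenyl in place of 2-cyanoethyl, where the chain gains only a double bond, gives a number 0.46 log units higher from compound 2 to compound 3 (beyond the scatter). At a second place on the shared core, hydroxymethyl in place of carbamoyl gives a number 0.61 log units higher from compound 1 to compound 3 (beyond the scatter), so each single change reaches beyond the scatter. Nothing available explains either step. As far as these compounds go, whether the first change gives a similar step with carbamoyl on the core remains open. So does the effect of an amine or a longer chain at this position.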